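Swapping Fluoro for Bromo at the Para Position

The source may report more compounds than this note shows. Statements on the series, on what has been measured and on what is new or still open speak of the compounds shown alone.

Measured compounds:
Compound 1 `CCOC(=O)c1cnc2n(c1=O)C(C)CC/C2=N\Nc1cccc(C(=O)O)c1`: in a functional assay on the whole organism for inhibition, with Rattus norvegicus as the target (on this read-out lower numbers stand for an effect already at smaller amounts and higher numbers for an effect only at larger amounts of compound), compound 1 gives 100 umol/kg.
Compound 2 `CC1C/C(=N\Nc2ccccc2)c2ncc(C(=O)O)c(=O)n2C1`: in this assay compound 2 gives 5.7 umol/kg.
Compound 3 `CC1CC/C(=N\Nc2ccc(F)cc2)c2ncc(C(=O)O)c(=O)n21`: in this assay compound 3 gives 12.2 umol/kg.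

Compound 3 stands second highest of the three numbers. Its nearest neighbour is compound 2, whose number is lower by a gap beyond the usual scatter; compound 1 lies much further away at a higher number. The series shares one core and varies only the ring attached through the amino group.

Compound 4 `CC1CC/C(=N\Nc2ccc(Br)cc2)c2ncc(C(=O)O)c(=O)n21` differs from compound 3 in a single place: bromo in place of fluoro on an aromatic carbon. A halogen replaces a halogen on the same aromatic carbon, para to a large group, with no change in ring count, hydrogen-bond donors, hydrogen-bond acceptors or charge.

Among the measured compounds shown here, no measured pair shows this swap, so the size of the step is uncertain. The step from compound 3 to compound 4 is expected to be small, a 1.2-fold lower number from compound 3 to compound 4 (0.09 log units; within the scatter), likely no further than the scatter in either direction. For compound 4 the estimated value is 10 umol/kg, within a range from 4 umol/kg to 30 umol/kg.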

Compound 4, dose for 50% inhibition: 0.8 umol/kg
Estimate against measurement, compound 4: 13-fold (1.10 log units) above, and the stated range ends above it.
By their numbers in this assay, from the lowest: compound 4; then compound 2; then compound 3; then compound 1.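

In this assay the exchange of fluoro for bromo gives a 15-fold lower number from compound 3 to compound 4 (1.18 log units; beyond the scatter) and lies far beyond the usual scatter, even though the count of rings, hydrogen-bond donors and hydrogen-bond acceptors and the net charge all stay the same. This place on the aromatic ring is therefore sensitive to which halogen it carries: the change from 4-fluorophenyl to 4-bromophenyl, one heavy atom for another, is enough to produce a large step. Nothing available here accounts for the size of this step.

The compounds shown leave open whether chloro or iodo at this place would stand nearer to compound 3 or to compound 4. They also leave open how a group other than a halogen, such as methyl, methoxy or an amine, would fare there.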